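Near-Zero Inhibition Across Three Close Analogues

The source may hold more compounds than are shown below. What is called first, only, known or untested is meant among the compounds shown, and "the series" means these compounds.

Three measured compounds share one core and differ only in the phenyl group attached to an amine nitrogen in a ring. Compound 1 `Nc1scc(CN2CCN(c3cc(Cl)cc(Cl)c3)CC2)c1C(=O)c1ccc(Cl)cc1` gives, in an assay on CHO cells for displacement of a labelled ligand from adenosine receptor A1 (Homo sapiens), read by scintillation counting, with a stated time of 120 min, tested at 10 uM (a lower number here means less inhibition, a higher number more inhibition at the concentration tested (going by the name of the read-out)), a value of 1%. Compound 2 `COc1ccc(N2CCN(Cc3csc(N)c3C(=O)c3ccc(Cl)cc3)CC2)cc1` gives 0%, and compound 3 `Nc1scc(CN2CCN(c3ccc(Cl)c(C(F)(F)F)c3)CC2)c1C(=O)c1ccc(Cl)cc1` gives 0%. Compound 1 holds the highest of these three numbers, but the margins are negligible: a number 1 percentage points lower from compound 1 to compound 2 (within the scatter), a number 1 percentage points lower from compound 1 to compound 3 (within the scatter), and no change at the digits printed from compound 2 to compound 3 (within the scatter). All three therefore sit at the bottom of the read-out, showing essentially no displacement of the labelled ligand at the concentration tested.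

Compound 4 `Nc1scc(CN2CCN(c3ccc(OC(F)(F)F)cc3)CC2)c1C(=O)c1ccc(Cl)cc1` has not yet been measured. Relative to compound 1 the change is 4-(trifluoromethoxy)phenyl in place of 3,5-dichlorophenyl on an amine nitrogen in a ring. The three measured steps all alter this same phenyl group, and none of them moved the number beyond the scatter, so the expectation for the new phenyl group is likewise no step beyond the scatter, namely no change at the digits printed from compound 1 to compound 4 (within the scatter). The estimate for compound 4 is 1%, with a range from -8% to 10%.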

Compound 4, a percentage reported as inhibition, at one concentration (the size of the read-out at that concentration, not a potency): 0%
Beside the measured number, compound 4's estimate is 1 percentage points above it; measured number inside the range.
By their numbers in this assay, from the lowest: compounds 2, 3, 4 and 1 (each within the scatter of the next).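

The 4-(trifluoromethoxy)phenyl group brings oxygen and fluorine to this amine nitrogen together, yet the read-out in this assay stays at the bottom of its range (a number 1 percentage points lower from compound 1 to compound 4 (within the scatter)). Set against the other fluorine-bearing group, the picture is the same (no change at the digits printed from compound 3 to compound 4 (within the scatter)), and the tightest comparison so far, trifluoromethyl in place of methyl on an oxygen on an aromatic ring, also leaves the number in place (no change at the digits printed from compound 2 to compound 4 (within the scatter)). Nothing measured here offers a reason for this flat result.

With all four compounds at the bottom of the read-out, these phenyl groups cannot be ranked against one another. Going by these compounds, whether a pyridine ring or a benzyl group on this nitrogen would give measurable inhibition stays open, as does the effect of changes elsewhere on the shared core.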